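Methyl for Bromo: An Expected Limit in Cytotoxicity

This account rests on a few compounds, and the source may have more. Where it says the series, first, only, none or still open, it means among the compounds named here.

The study follows three compounds through an ADME assay on MT4 cells (Homo sapiens) for cytotoxicity, read by MTT assay, with a stated time of 96 h; a higher number here means that more compound is tolerated, a lower number that less compound is tolerated. Compound 1 is `Cc1ccc(-c2nn(-c3ccccc3)cc2CNc2ccccc2)cc1`, compound 2 is `FC(F)(F)c1ccc(NCc2cn(-c3ccccc3)nc2-c2ccc(Br)cc2)cc1` and compound 3 is `Clc1ccc(NCc2cn(-c3ccccc3)nc2-c2ccc(Br)cc2)cc1`. In this assay compound 1 gives only the limit of the assay, > 100000 nM, and no number. Compound 2 likewise reaches only a limit, > 100000 nM. Compound 3, entered twice, gives a limit both times, > 100000 nM; > 100000 nM (2 entries). Within the data shown here, compound 2 therefore stands at the limit of > 100000 nM in this assay, at which 2 of the 3 values shown sit, and since none of the three values is a number, no step between measured compounds can be drawn from them.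

The next compound, compound 4, is `Cc1ccc(-c2nn(-c3ccccc3)cc2CNc2ccc(C(F)(F)F)cc2)cc1`. Set against compound 2 the change is methyl in place of bromo on an aromatic carbon. Among the measured compounds shown here, compound 1 already carries methyl at that place and gives only a limit, > 100000 nM, which is the one guide the series offers. The step in this assay is expected to be a number no higher from compound 2 to compound 4 (the limit leaves the size open), that is, none beyond the usual scatter. Compound 4 is accordingly expected to give 100000 nM, within a range from 50000 nM to 200000 nM, and most probably as a limit once more rather than as a number.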

Compound 4, half-maximal cytotoxic concentration: > 100000 nM
Compound 4 gave a limit, no number (the forecaster's own chance of this, stated with the estimate: 85%); the middle value sits exactly at the limit.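

Compound 1, compound 2 and compound 4 all stand at limits in this assay, not at numbers, and no step can be read from compound 2 to compound 4 or from compound 1 to compound 4. The compounds shown leave open at what concentration each becomes cytotoxic, and whether methyl in place of bromo changes that at all.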